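The source may report more compounds than this note shows. Statements on the series, on what has been measured and on what is new or still open speak of the compounds shown alone.

Working notes on the series. The shared core carries an acylguanidine and a methylsulfonyl group; the position ortho to the methylsulfonyl group is the variable one. Compound 1 `CCCc1cc(C)c(C(=O)N=C(N)N)cc1S(C)(=O)=O` gives 5.7 nM in a functional assay for inhibition of sodium/hydrogen exchanger (Oryctolagus cuniculus); a lower number here means a stronger inhibitor, a higher number a weaker inhibitor. Compound 2 `Cc1cc(-c2cc(Cl)cc(Cl)c2)c(S(C)(=O)=O)cc1C(=O)N=C(N)N` gives 130 nM in this assay, with a 23-fold higher number from compound 1 to compound 2 (1.36 log units; beyond the scatter). Compound 3 `Cc1cc(N2CCCC(O)C2)c(S(C)(=O)=O)cc1C(=O)N=C(N)N` gives 30 nM in this assay and stands second highest of the three numbers: a 5.3-fold higher number from compound 1 to compound 3 (0.72 log units; beyond the scatter), while a 4.3-fold lower number from compound 2 to compound 3 (0.64 log units; beyond the scatter).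

Compound 4 `Cc1cc(Nc2ccccc2)c(S(C)(=O)=O)cc1C(=O)N=C(N)N` differs from compound 3 in one place: anilino in place of 3-hydroxypiperidin-1-yl on an aromatic carbon. Among the compounds with values here, two measured steps bear on this. The entry of a six-membered aromatic ring of carbon only in place of a chain raised the number, as a 23-fold higher number from compound 1 to compound 2 (1.36 log units; beyond the scatter) shows, and the replacement of such a ring by the 3-hydroxypiperidin-1-yl lowered it, as a 4.3-fold lower number from compound 2 to compound 3 (0.64 log units; beyond the scatter) shows. Anilino brings back an aromatic ring of carbon only, now linked through nitrogen with one hydrogen-bond donor. A modest rise in this assay is therefore expected, short of the dichlorophenyl case, with a 2.0-fold higher number from compound 3 to compound 4 (0.30 log units; within the scatter). For compound 4 the estimate in this assay is 60 nM, within 20 nM to 200 nM.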

Compound 4, half-maximal inhibitory concentration: 21 nM
For compound 4 the middle estimate is 2.9-fold (0.46 log units) above the measured one; low and high end bracket the measured number.
By their numbers in this assay, from the lowest: compound 1; then compounds 4 and 3 (each within the scatter of the next); then compound 2.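

In this assay, anilino and 3-hydroxypiperidin-1-yl are not separated at this position (a 1.4-fold lower number from compound 3 to compound 4 (0.15 log units; within the scatter)), so an aromatic ring of carbon only, when joined through nitrogen, reads the same here as a six-membered non-aromatic ring. Anilino also sits well clear of 3,5-dichlorophenyl (a 6.2-fold lower number from compound 2 to compound 4 (0.79 log units; beyond the scatter)), but that step changes both the link and the chlorines, so it cannot say which of them matters, and propyl still holds the lower number (a 3.7-fold higher number from compound 1 to compound 4 (0.57 log units; beyond the scatter)). Nothing available here accounts for these steps.

Unsubstituted phenyl joined directly to the core would separate the effect of the nitrogen link from that of the chlorines. Going by these compounds, whether a chain longer than propyl, or a simple piperidin-1-yl without the hydroxyl, holds the number near that of compound 1 remains open.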